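The compounds below may be only part of what the source reports. "The series", "measured", "known", "first", "only" and "open" are said of these compounds alone.

Measured compounds:
- compound 1, `CCCCNS(=O)(=O)c1ccc(Nc2ncc3c(n2)N(C2CCCC2)[C@H](CC)C(=O)N3C)cc1`: in a functional assay on A549 cells (Homo sapiens) for antiproliferative activity, read by CCK-8 assay, with a stated time of 72 h (on this read-out lower numbers stand for stronger inhibition of growth and higher numbers for weaker inhibition of growth), compound 1 gives 477 nM
- compound 2, `CCCNS(=O)(=O)c1ccc(Nc2ncc3c(n2)N(C2CCCC2)[C@H](CC)C(=O)N3C)cc1`: in this assay compound 2 gives 563 nM
- compound 3, `CCCNC(=O)c1ccc2c(ccn2-c2ncc3c(n2)N(C2CCCC2)[C@H](CC)C(=O)N3C)c1`: in this assay compound 3 gives 1640 nM

Compounds 1 and 2 share one core and differ in a single place. Going from compound 2 to compound 1 the change is methyl in place of hydrogen on a saturated chain carbon, three bonds along the chain from a sulfonamide nitrogen, and the step it made in this assay is a 1.2-fold lower number from compound 2 to compound 1 (0.07 log units; within the scatter), so the two values cannot be ordered against each other.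

Compound 3 carries a different core, and how its core differs from that of compound 2 is not broken down here. Its value in this assay stands highest of the three, beyond the scatter from compound 2 and from compound 1.

Compound 4, `CCCCNC(=O)c1ccc2c(ccn2-c2ncc3c(n2)N(C2CCCC2)[C@H](CC)C(=O)N3C)c1`, has not yet been measured in this assay. It is derived from compound 3 by methyl in place of hydrogen on a saturated chain carbon, three bonds along the chain from an amide-type nitrogen. Going by the values given here, this is the same kind of change as the one from compound 2 to compound 1, but the place differs: here the saturated chain carbon sits three bonds from an amide-type nitrogen, whereas in the earlier pair it sits three bonds from a sulfonamide nitrogen. Because the earlier pair showed a 1.2-fold lower number from compound 2 to compound 1 (0.07 log units; within the scatter), the expected step in this assay from compound 3 to compound 4 is similarly small, a 1.2-fold lower number from compound 3 to compound 4 (0.07 log units; within the scatter). Compound 4 is therefore estimated at 1400 nM in this assay, with a likely range from 700 nM to 2800 nM.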

Compound 4, concentration for 50% growth inhibition: 1160 nM
The estimate for compound 4 lay 1.2-fold (0.08 log units) above the measured number; low and high end bracket the measured number.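

In this assay, the step on the second core is a 1.4-fold lower number from compound 3 to compound 4 (0.15 log units; within the scatter), and it sits close to the step seen earlier for the same change on the first core: the same change on two cores in this assay, a 1.2-fold lower number (0.07 log units; within the scatter) from compound 2 to compound 1 and a 1.4-fold lower number (0.15 log units; within the scatter) from compound 3 to compound 4, 1.2-fold (0.08 log units) apart, within the scatter of two such steps

Taken together, the two pairs show that, on these two cores, going from a propyl to a butyl chain left the number within the scatter each time, so the small step seen on the core of compound 2 carried over to the core of compound 3. They do not show that the methyl has any real effect in either direction, since neither step can be told apart from the scatter, and two pairs cannot say whether a step this small would also hold on a third core or what lies behind it.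

The compounds shown leave open how a longer chain such as pentyl, a branched chain such as isobutyl, or a chain ending in an amine or a carboxylic acid would behave on either core. They also leave open what a shorter chain, such as ethyl or methyl, would give there, and so whether the number stays this flat across a wider range of chain lengths.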